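This account rests on a few compounds, and the source may have more. Where it says the series, first, only, none or still open, it means among the compounds named here.

Three compounds share one core and differ only in the aryl group attached to a carbonyl carbon. In a functional assay on C8166 cells (Homo sapiens) for cytotoxicity, read by MTT assay (a lower number here means that less compound is tolerated, a higher number that more compound is tolerated), compound 1 `Cc1cccc(C(=O)Nc2cc(Cl)ccc2OCC(=O)Nc2ccc(S(N)(=O)=O)cc2C)c1` gives 52900 nM, compound 2 `Cc1cc(S(N)(=O)=O)ccc1NC(=O)COc1ccc(Cl)cc1NC(=O)c1ccccc1[N+](=O)[O-]` gives 54800 nM, and compound 3 `COc1ccc(C(=O)Nc2cc(Cl)ccc2OCC(=O)Nc2ccc(S(N)(=O)=O)cc2C)cc1` gives 69500 nM. Compound 3 shows the highest of the three numbers, yet a 1.3-fold higher number from compound 1 to compound 3 (0.12 log units; within the scatter) and a 1.3-fold higher number from compound 2 to compound 3 (0.10 log units; within the scatter) both lie within the scatter, as does a 1.0-fold higher number from compound 1 to compound 2 (0.02 log units; within the scatter). Compound 4 `Cc1cc(S(N)(=O)=O)ccc1NC(=O)COc1ccc(Cl)cc1NC(=O)c1cc(Cl)cc(Br)c1` carries the change (3-bromo-5-chlorophenyl in place of 4-methoxyphenyl on a carbonyl carbon). Each measured step swapped this same aryl group without moving the number beyond the scatter, so for compound 4 no step beyond the scatter is expected in this assay. Compound 4 is estimated at 60000 nM, with a range from 30000 nM to 120000 nM. That expected value corresponds to a step of a 1.2-fold lower number from compound 3 to compound 4 (0.06 log units; within the scatter).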

Compound 4, half-maximal cytotoxic concentration: 114000 nM
Beside the measured number, compound 4's estimate is 1.9-fold (0.28 log units) below it; measured number inside the range.
By their numbers in this assay, from the lowest: compounds 1, 2, 3 and 4 (each within the scatter of the next, the first and the last beyond it).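

Going by these compounds alone, on this carbonyl carbon, 3-bromo-5-chlorophenyl brings the first steps beyond the scatter in this assay with a 2.2-fold higher number from compound 1 to compound 4 (0.33 log units; beyond the scatter) and a 2.1-fold higher number from compound 2 to compound 4 (0.32 log units; beyond the scatter) while a 1.6-fold higher number from compound 3 to compound 4 (0.21 log units; within the scatter) stays within it. Changing this aryl group can therefore move the tolerated concentration, though only modestly. Nothing available explains this shift.

On these data alone, it remains open whether the bromine, the chlorine or the pair matters. As far as these compounds go, it is also open how the number would respond to a non-aromatic group on this carbonyl carbon, such as cyclohexyl or a short chain ending in an amine.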